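The compounds below may be only part of what the source reports. "The series", "measured", "known", "first", "only" and "open" are said of these compounds alone.

Measured so far in an assay on isolated protein for binding affinity to C-X-C chemokine receptor type 3 (Homo sapiens); on this read-out lower numbers stand for stronger inhibition and higher numbers for weaker inhibition:

Compound 1, `CC[C@H]1CN(c2ncc(-c3nnc[nH]3)cc2Cl)CCN1C1CCN(Cc2ccc(Cl)cc2F)CC1`: 6.8 nM
Compound 2, `CC[C@H]1CN(c2ncc(-c3ncon3)cc2Cl)CCN1C1CCN(Cc2ccc(Cl)cc2F)CC1`: 286 nM

For the measured compounds named here, compound 2 stands at the higher of the two numbers so far. Going by the values given here, its nearest neighbour is compound 1, and the only step measured, a 42-fold higher number from compound 1 to compound 2 (1.62 log units; beyond the scatter), separates the two; the sole change there is the exchange of one five-membered azole for another on the shared core.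

Compound 3, `CC[C@H]1CN(c2ncc(-c3nnco3)cc2Cl)CCN1C1CCN(Cc2ccc(Cl)cc2F)CC1`, continues along the same line: 1,3,4-oxadiazol-2-yl in place of 1,2,4-oxadiazol-3-yl on an aromatic carbon. As in the step from compound 1 to compound 2, nothing else on the molecule moves.

Among the compounds with values here, the one measured step bears directly on this change, since it shows that swapping the azole at this position can shift this assay by a large amount. That step, however, went from a ring with a donor to one without; the present change keeps compound 3 with no donor, as counted above. A step of that size is therefore not assumed again. The expectation for compound 3 is a number near compound 2, with the step of a 1.4-fold lower number from compound 2 to compound 3 (0.16 log units; within the scatter) estimated to stay within the scatter, and the estimate for compound 3 in this assay is 200 nM, in the range 50 nM to 800 nM.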

Compound 3, half-maximal inhibitory concentration: 1.4 nM
Compound 3: the middle estimate sits 140-fold (2.15 log units) above what was measured; the measured number lies below the stated range.
By their numbers in this assay, from the lowest: compound 3; then compound 1; then compound 2.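

In this assay, this position turns out to respond to how the atoms are arranged within the azole and not only to which atoms it holds: a 200-fold lower number from compound 2 to compound 3 (2.31 log units; beyond the scatter) accompanies an exchange of 1,2,4-oxadiazol-3-yl for 1,3,4-oxadiazol-2-yl, two groups with identical atoms and identical counts of hydrogen-bond donors and acceptors. A hydrogen-bond donor on the azole is also not needed for a low number among these compounds, as a 4.9-fold lower number from compound 1 to compound 3 (0.69 log units; beyond the scatter) leads from 4H-1,2,4-triazol-3-yl to 1,3,4-oxadiazol-2-yl with 0 hydrogen-bond donors, so the loss of the donor cannot alone account for a 42-fold higher number from compound 1 to compound 2 (1.62 log units; beyond the scatter). No measurement at hand explains the large gap between the two oxadiazoles.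

From the compounds shown here alone, it remains open how other groups at this position would compare with 1,3,4-oxadiazol-2-yl, for instance 1,3,4-thiadiazol-2-yl, tetrazol-5-yl, a primary amide or a carboxylic acid. Also open, going by these compounds, is whether 1,3,4-oxadiazol-2-yl would keep its standing with a methyl group or an amine on its free ring carbon, and whether the order of these three azoles would hold with other groups elsewhere on the shared core.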